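Second 4-chlorophenyl on the ether carbon of compound 1

A few compounds are considered here, and "the series" means these few. Any claim that something is new, unique, unknown or untested is made for them only; others in the source may bear on it.

In a functional assay on cells (T-cell line, Homo sapiens) for inhibition (a higher number here means a weaker inhibitor, a lower number a stronger inhibitor), compound 1 (`COc1ccc(CCCN2CCC(COCc3ccc(Cl)cc3)CC2)cc1`) gives 500 nM, the middle of three measured numbers. Compound 2 (`COc1ccc(CCCN2CCC(COCc3ccc(Cl)c(Cl)c3)CC2)cc1`) gives 200 nM, and compound 3 (`COc1ccc(CCCN2CCC(COCC3CCCCC3)CC2)cc1`) gives 3000 nM.

Compound 4 (`COc1ccc(CCCN2CCC(COC(c3ccc(Cl)cc3)c3ccc(Cl)cc3)CC2)cc1`) is not yet measured. It differs from compound 1 as follows: 4-chlorophenyl in place of hydrogen on a saturated chain carbon bound to an aromatic carbon and an oxygen on a saturated carbon. That is, 4-chlorophenyl in place of hydrogen on a saturated chain carbon bound to an aromatic carbon and an oxygen on a saturated carbon.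

Among the measured compounds shown here, no measured step makes this change, so the evidence is indirect. Adding chloro gives a modest gain, a 2.5-fold lower number from compound 1 to compound 2 (0.40 log units; beyond the scatter). Replacing the aromatic ring with cyclohexyl costs more, a 6.0-fold higher number from compound 1 to compound 3 (0.78 log units; beyond the scatter) and a 15-fold higher number from compound 2 to compound 3 (1.18 log units; beyond the scatter). Both trends favour the added chlorinated aromatic ring, but neither tests a second ring on this carbon, so the direction is tentative.

A modest step to a lower number is expected, a 2.5-fold lower number from compound 1 to compound 4 (0.40 log units; beyond the scatter). Compound 4 is estimated at 200 nM, with an expected range of 50 nM to 800 nM.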

Compound 4, half-maximal inhibitory concentration: 1100 nM
Compound 4: middle estimate off by 5.5-fold (0.74 log units), on the low side, outside the stated range (above it).
By their numbers in this assay, from the lowest: compound 2; then compound 1; then compound 4; then compound 3.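

In this assay, among the compounds shown here, this is the first change at the saturated chain carbon bound to an aromatic carbon and an oxygen on a saturated carbon itself, rather than to the ring it carries. Placing 4-chlorophenyl in place of hydrogen there gives a 2.2-fold higher number from compound 1 to compound 4 (0.34 log units; beyond the scatter) and so runs opposite to the gain from chloro on the aromatic ring and the loss from cyclohexyl in place of that ring: what favours the existing ring does not carry over to a second ring on this carbon. No measurement at hand accounts for the direction of this step.

The compounds shown leave open whether the rise in the number follows from any group on this carbon or is specific to 4-chlorophenyl. A methyl group or an unsubstituted phenyl in place of the same hydrogen would separate these two readings.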